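Working notes: 4-fluorophenyl to 4-ethylphenyl in the series

The source may hold more compounds than are shown below. What is called first, only, known or untested is meant among the compounds shown, and "the series" means these compounds.

Measured in a functional assay on MCF7 cells (Homo sapiens) for antiproliferative activity, read by sulforhodamine B assay, with a stated time of 48 h; on this read-out higher numbers stand for weaker inhibition and lower numbers for stronger inhibition:
- compound 1 `O=C1NCCN1c1ccc(S(=O)(=O)Nc2ccc3[nH]ccc3c2)cc1` gives 170 nM
- compound 2 `O=C1NCCN1c1ccc(S(=O)(=O)Nc2ccc(F)cc2)cc1` gives 690 nM
- compound 3 `O=C1NCCN1c1ccc(S(=O)(=O)Nc2ccc(I)cc2)cc1` gives 600 nM

Compound 2 stands at the upper end of these numbers, level with compound 3 within the scatter, as the step of a 1.2-fold lower number from compound 2 to compound 3 (0.06 log units; within the scatter) shows. Compound 1 reads 170 nM against compound 2 at 690 nM, a clearly lower number.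

The next compound to be measured is compound 4 `CCc1ccc(NS(=O)(=O)c2ccc(N3CCNC3=O)cc2)cc1`, which carries ethyl in place of fluoro on an aromatic carbon, para to a large group: ethyl in place of fluoro on an aromatic carbon. Going by the values given here, only one measured step changes this same place, namely a 1.2-fold lower number from compound 2 to compound 3 (0.06 log units; within the scatter), and it stays within the scatter. Compound 1 differs from compound 2 in another part of the structure and offers no direct guide to this change. Ethyl itself has no measured precedent in the series, so the expectation rests on a single step and the range is kept wide. With that step as the guide, no change beyond the scatter is expected in this assay, with at most a small drift toward a lower number. The estimated step is a 1.3-fold lower number from compound 2 to compound 4 (0.10 log units; within the scatter). The estimate for compound 4 is 550 nM, with an expected range of 220 nM to 1400 nM.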

Compound 4, half-maximal inhibitory concentration: 810 nM
Beside the measured number, compound 4's estimate is 1.5-fold (0.17 log units) below it, and the stated range covers the measured number.
By their numbers in this assay, from the lowest: compound 1; then compounds 3, 2 and 4 (each within the scatter of the next).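

In this assay, ethyl in place of fluoro gives a 1.2-fold higher number from compound 2 to compound 4 (0.07 log units; within the scatter) and ethyl in place of iodo gives a 1.4-fold higher number from compound 3 to compound 4 (0.13 log units; within the scatter) as the second step at the same place. Before this result, the place on the aromatic carbon para to a large group had been read only with two halogens, fluoro and iodo; a two-carbon group now joins them, and all three compounds lie within the scatter of one another, so none of the three groups separates from the others in this read-out. No measurement at hand offers an explanation for this flat reading.

Still open, on these data alone, is whether an amine, a carboxylic acid or a longer chain such as butyl at this same place would stay within the scatter of these three compounds or move the number beyond it. Also open, as far as these compounds go, is whether fluoro, iodo and ethyl would remain equally level on a different carbon of this six-membered aromatic ring, as all three readings come from the one place.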